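A Chlorine Added to the Benzoyl Ring

The source may report more compounds than this note shows. Statements on the series, on what has been measured and on what is new or still open speak of the compounds shown alone.

Compound 1, `Cc1nnc(CN2CCCC2)n1-c1ccc(Cl)cc1Cc1ccccc1`: 36 mg/kg
Compound 2, `Cc1nnc(CN2CCCC2)n1-c1ccc(Cl)cc1C(=O)c1ccccc1`: 0.4 mg/kg
Compound 3, `CNCc1nnc(C)n1-c1ccc(Cl)cc1C(=O)c1ccccc1`: 0.1 mg/kg

Of the compounds shown here, three have been measured in a functional assay on the whole organism (strain CF-1) for inhibition, with Mus musculus as the target; a lower number here means that less compound is needed, a higher number that more compound is needed for the effect. Compound 2 stands second highest of the three numbers. Its nearest neighbour is compound 3, reached by a 4.0-fold lower number from compound 2 to compound 3 (0.60 log units; beyond the scatter); its furthest is compound 1, separated from it by a 90-fold lower number from compound 1 to compound 2 (1.95 log units; beyond the scatter).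

The unmeasured compound 4, `Cc1nnc(CN2CCCC2)n1-c1ccc(Cl)cc1C(=O)c1ccccc1Cl`, differs from compound 2 in a single place: chloro in place of hydrogen on an aromatic carbon. Read one bond further out, the phenyl of the benzoyl group becomes a 2-chlorophenyl.

Neither measured step is of this kind. The step from compound 1 to compound 2 replaced benzyl with benzoyl, altering the link between the two rings; the step from compound 2 to compound 3 exchanged one amine for another on the side chain. Among the compounds with values here, neither touches the benzoyl ring itself, so no measured step bears directly on the present change. With no guide from the measured compounds, the expected step of a 1.3-fold lower number from compound 2 to compound 4 (0.12 log units; within the scatter) is one that stays within the scatter. Compound 4 is therefore estimated at about 0.3 mg/kg in this assay, within a range from 0.08 mg/kg to 1.2 mg/kg. Within the data shown here, the range is wide; no measured step covers a change of this sort.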

Compound 4, dose for half-maximal effect: 1.8 mg/kg
Compound 4: middle estimate off by 6.0-fold (0.78 log units), on the low side, and the stated range ends below it.
By their numbers in this assay, from the lowest: compound 3; then compound 2; then compound 4; then compound 1.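

In this assay, the benzoyl ring proves to be a place where even one added atom counts: chloro in place of hydrogen, on an aromatic carbon ortho to a large group, gives a 4.5-fold higher number from compound 2 to compound 4 (0.65 log units; beyond the scatter), so this single change moves the number in the opposite direction from the two earlier steps. The change does not cancel the large gain seen with the benzoyl link, as (2-chlorophenyl)carbonyl in place of benzyl still gives a 20-fold lower number from compound 1 to compound 4 (1.30 log units; beyond the scatter). Nothing available here accounts for the rise caused by the chloro.

The compounds shown cover only one group at one place on this ring, so they leave open whether a fluoro or a methoxy group at the same place would raise the number as well, and what chloro would do elsewhere on the ring. They also leave open whether the same chloro would have a step of similar size when the pyrrolidin-1-yl is replaced by the methylamino of compound 3, since the chloro is seen alongside only one amine.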